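Chloro-to-hydrogen step on the bicyclic core, second pair

The compounds below may be only part of what the source reports. "The series", "measured", "known", "first", "only" and "open" are said of these compounds alone.

Measured so far in a functional assay on 786-0 cells (Homo sapiens) for cytotoxicity, read by sulforhodamine B assay, with a stated time of 48 h; on this read-out higher numbers stand for lower toxicity in this test and lower numbers for higher toxicity in this test:
compound 1 `ClCc1ccccc1Cn1cnc2c(Cl)nc(Cl)nc21` — 6450 nM
compound 2 `ClCc1ccccc1Cn1cnc2c(Cl)ncnc21` — 83200 nM
compound 3 `ClCc1ccc(Cn2cnc3nc(Cl)nc(Cl)c32)cc1` — 7410 nM

Compound 1 and compound 3 share the same atoms joined differently; the difference between the two cores is not broken down here. Their values in this assay lie within the scatter of each other. Compound 2 carries the change hydrogen in place of chloro on an aromatic carbon relative to compound 1, and this gave a 13-fold higher number from compound 1 to compound 2 (1.11 log units; beyond the scatter).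

Compound 4 `ClCc1ccc(Cn2cnc3ncnc(Cl)c32)cc1` is not yet measured. It carries hydrogen in place of chloro on an aromatic carbon relative to compound 3. The two place descriptions are the same word for word, so this is the same change as that from compound 1 to compound 2.

For compound 4 in this assay a step of about a 12-fold higher number from compound 3 to compound 4 (1.08 log units; beyond the scatter) is expected, because the same change gave a 13-fold higher number from compound 1 to compound 2 (1.11 log units; beyond the scatter). The estimate for compound 4 is 90000 nM, with a range from 35000 nM to 250000 nM.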

Compound 4, concentration lethal to 50% of the cells: 5490 nM
Compound 4: middle estimate off by 16-fold (1.21 log units), on the high side; the measured number lies below the stated range.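

In this assay, hydrogen in place of chloro on the core of compound 3 gave a 1.3-fold lower number from compound 3 to compound 4 (0.13 log units; within the scatter), so no change can be read on this core. The step seen on the core of compound 1 therefore does not carry over to the core of compound 3: the same change on two cores in this assay, a 13-fold higher number (1.11 log units; beyond the scatter) from compound 1 to compound 2 and a 1.3-fold lower number (0.13 log units; within the scatter) from compound 3 to compound 4, 17-fold (1.24 log units) apart, beyond the scatter of two such steps

This shows that, for these two pairs, the outcome of the change differs with the core; it does not show which difference between the cores is responsible, and two pairs set no rule for other cores.

Open, from the compounds shown here alone, is how each core responds to an amine or a methoxy group in place of chloro on that carbon. Also open, going by these compounds, is what a hydroxymethyl group in place of the chloromethyl group would give.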